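This account rests on a few compounds, and the source may have more. Where it says the series, first, only, none or still open, it means among the compounds named here.

Compound 3 `CC(C)(C)C(=O)C(C#N)Oc1c(Br)cc(Br)cc1Oc1ccc(Br)cc1Br` is one of three measured compounds that share a core and differ only in the group carried on an oxygen on an aromatic ring. In a functional assay on U-937 cells (Homo sapiens) for cytotoxicity, read by MTT assay, with a stated time of 24 h (a higher number here means a weaker inhibitor, a lower number a stronger inhibitor), compound 3 gives 32.5 ug/mL. Compound 1 `OCCCOc1c(Br)cc(Br)cc1Oc1ccc(Br)cc1Br` gives 32.3 ug/mL, and compound 2 `COc1c(Br)cc(Br)cc1Oc1ccc(Br)cc1Br` gives 34.5 ug/mL. The three numbers sit together: the step of a 1.0-fold higher number from compound 1 to compound 3 (0.00 log units; within the scatter) and the step of a 1.1-fold lower number from compound 2 to compound 3 (0.03 log units; within the scatter) are both within the scatter, as is a 1.1-fold higher number from compound 1 to compound 2 (0.03 log units; within the scatter). Compound 4 `Brc1ccc(Oc2cc(Br)cc(Br)c2OCc2ccccc2)c(Br)c1` has not yet been measured. It differs from compound 3 in one place: benzyl in place of cyano((tert-butyl)carbonyl)methyl on an oxygen on an aromatic ring. Every measured step at that oxygen, whether hydrogen in place of 2-hydroxyethyl, cyano((tert-butyl)carbonyl)methyl in place of 3-hydroxypropyl, or cyano((tert-butyl)carbonyl)methyl in place of methyl, stayed within the scatter. Within the data shown here, no measured step carries a benzyl there, so nothing is known of that group itself. On the evidence of compounds 1, 2 and 3, the expectation for compound 4 is no step beyond the scatter, that is a 1.0-fold lower number from compound 3 to compound 4 (0.01 log units; within the scatter). Compound 4 is therefore estimated at 32 ug/mL, with a range from 18 ug/mL to 55 ug/mL.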

Compound 4, half-maximal inhibitory concentration: 29 ug/mL
Estimate against measurement, compound 4: 1.1-fold (0.04 log units) above, and the stated range covers the measured number.
By their numbers in this assay, from the lowest: compounds 4, 1, 3 and 2 (each within the scatter of the next).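

Benzyl is the first group on this oxygen to carry an aromatic ring of its own, and in this assay each step to it stays within the scatter: a 1.1-fold lower number from compound 3 to compound 4 (0.05 log units; within the scatter) and a 1.2-fold lower number from compound 2 to compound 4 (0.08 log units; within the scatter) and also a 1.1-fold lower number from compound 1 to compound 4 (0.05 log units; within the scatter) in turn. Among these four compounds, then, the number does not separate a group with a six-membered aromatic ring of carbon only and no hydrogen-bond acceptors from the open-chain groups carried by compounds 1, 2 and 3. Nothing given here accounts for this flat response at the oxygen.

From the compounds shown here alone, it remains open whether a charged group such as an amine or a carboxylic acid on this oxygen would give a step beyond the scatter. Going by these compounds, all four compounds share the same core, so the effect of any change elsewhere on it also remains unknown.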